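The source may hold more compounds than are shown below. What is called first, only, known or untested is meant among the compounds shown, and "the series" means these compounds.

Measured so far:
compound 1 `C=C(c1ccc(OC)c(F)c1)C1COC2(CCCC2)OO1`: 9700 nM
compound 2 `C=C(c1cc(Cl)cc(Cl)c1OCc1ccccc1)C1COC(C)(C)OO1`: 58400 nM

Both values come from a functional assay on A549 cells (Homo sapiens) for inhibition, read by MTT assay, with a stated time of 72 h; a lower number here means a stronger inhibitor, a higher number a weaker inhibitor. Compound 1, at 9700 nM, holds the lower of the two numbers, and its gap to compound 2 lies beyond the scatter. The two compounds differ in more than one place, so that gap isolates no single change.

Compound 3 `C=C(c1ccc(F)c(F)c1)C1COC2(CCCC2)OO1` is still unmeasured. It carries fluoro in place of methoxy on an aromatic carbon, ortho to a fluoro group and para to a large group (fluoro in place of methoxy on an aromatic carbon). Among the compounds with values here, no measured pair shows this change, so the expectation is loose: no step beyond the scatter in this assay, leaning slightly towards a higher number. The expected change is a 1.2-fold higher number from compound 1 to compound 3 (0.09 log units; within the scatter). For compound 3 the estimate is 12000 nM, with an expected range of 5000 nM to 30000 nM.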

Compound 3, half-maximal inhibitory concentration: 11700 nM
Compound 3: the middle estimate sits 1.0-fold (0.01 log units) above what was measured, within the range that was stated.
By their numbers in this assay, from the lowest: compounds 1 and 3 (each within the scatter of the next); then compound 2.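

In this assay the step is a 1.2-fold higher number from compound 1 to compound 3 (0.08 log units; within the scatter) for fluoro in place of methoxy on an aromatic carbon, ortho to a fluoro group and para to a large group. Within the data shown here, this is the first one-place comparison, and at this position the read-out does not separate the two groups, even though methoxy carries 2 heavy atoms and 1 hydrogen-bond acceptor and fluoro carries 1 heavy atom and 0 hydrogen-bond acceptors. No measured evidence bears on why the two groups read alike.

As far as these compounds go, how an amine or a carboxylic acid at this position would compare remains open, and so does whether any group there gives a step beyond the scatter. The gap between these two compounds and compound 2 also stays unassigned to any single change, since compound 2 differs from each of them in more than one place.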